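A Chlorophenyl Swap on a Weak Cell-Growth Inhibitor

The source may hold more compounds than are shown below. What is called first, only, known or untested is meant among the compounds shown, and "the series" means these compounds.

Compound 1 `C#CCSc1nc(Nc2ccc(OC)cc2)c(C#N)c(-c2ccccc2)n1` is tested in a functional assay on MCF7 cells (Homo sapiens) for inhibition, read by MTT assay, with a stated time of 72 h (a higher number here means a weaker inhibitor, a lower number a stronger inhibitor), where compound 1 gives 35600 nM. Within the data shown here, it is the only compound with an actual number in this assay, so it cannot be placed above or below another measured compound. Compound 2 `C#CCSc1nc(Nc2cccc(C(F)(F)F)c2)c(C#N)c(-c2ccccc2)n1` returns only a limit of the assay, > 128000 nM. That limit is recorded as the limit of > 128000 nM in this assay, at which 1 of the 2 values shown sits. Compound 3 `C#CCSc1nc(Nc2ccccc2Cl)c(C#N)c(-c2ccccc2)n1` has not yet been measured; it differs from compound 1 by 2-chlorophenyl in place of 4-methoxyphenyl on a nitrogen on an aromatic ring. Among the measured compounds shown here, no measured pair shows a comparable change, so the expectation rests on the weak inhibition of compound 1 and on the fact that a different aryl group on the same nitrogen in compound 2 reached only the assay limit. The step from compound 1 to compound 3 is expected to be a 1.7-fold higher number from compound 1 to compound 3 (0.23 log units; within the scatter), a modest loss of potency. Compound 3 is therefore expected to give 60000 nM, within a range from 20000 nM to 128000 nM.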

Compound 3, half-maximal inhibitory concentration: 24200 nM
Compound 3: middle estimate off by 2.5-fold (0.39 log units), on the high side; low and high end bracket the measured number.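

Among these compounds, the change of 4-methoxyphenyl to 2-chlorophenyl on this nitrogen gives the first step that can be read at this position: a 1.5-fold lower number from compound 1 to compound 3 (0.17 log units; within the scatter). In this assay, these two aryl groups therefore cannot be told apart, even though the group that enters carries a chlorine and the one that leaves carries an oxygen. Compound 2, with a different aryl group on the same nitrogen, gives no number, only a limit of the assay: the limit of > 128000 nM in this assay, at which 1 of the 3 values shown sits.

Still open, on these data alone, is what an unsubstituted phenyl, or a phenyl carrying a carboxylic acid or an amine, would give on this nitrogen. Also open, as far as these compounds go, is whether a change elsewhere on the shared core, such as a longer chain on the sulfur, would move the number beyond the usual scatter.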